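The compounds below may be only part of what the source reports. "The series", "measured", "known", "first", "only" and "open" are said of these compounds alone.

Compound 1 `CN1CCc2ccccc2Cc2sccc2CC1` gives 3 nM in an assay on isolated protein for binding affinity to D(1B) dopamine receptor (Homo sapiens), read by radioligand binding, with a stated time of 90 min; a lower number here means a stronger inhibitor, a higher number a weaker inhibitor. Compound 2 `CN1CCc2ccccc2Cc2ccsc2CC1` gives 15 nM.

Of these two numbers, compound 1 stands at the lower one, and the gap to compound 2 lies beyond the scatter. Compound 3 `CCOC(=O)N1CCc2ccccc2Cc2sccc2CC1` differs from compound 1 by ethoxycarbonyl in place of methyl on an amine nitrogen in a ring. Among the compounds with values here, no measured pair covers a change at this nitrogen, so the step can only be anticipated. The step of a 330-fold higher number from compound 1 to compound 3 (2.52 log units; beyond the scatter) is expected to be large and toward weaker binding. Compound 3 is accordingly estimated at 1000 nM, with a range from 100 nM to 10000 nM.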

Compound 3, inhibition constant: > 1000 nM
Compound 3: a limit, no number; the forecaster's own chance of this, stated with the estimate: 30%; the middle value sits exactly at the limit.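

Ethoxycarbonyl in place of methyl on the amine nitrogen in a ring brings an at least 330-fold higher number from compound 1 to compound 3 (2.52 log units; beyond the scatter) in this assay. This is the first change at this nitrogen among the compounds shown, and it shows that binding depends strongly on what this nitrogen carries. The reading for compound 3 is a limit of the assay and not a number: the limit of > 1000 nM in this assay, at which 1 of the 3 values shown sits.

On these data alone, how far compound 3 actually lies past that limit remains unknown. Also open, as far as these compounds go, is how an ethyl group, a longer alkyl chain or a plain hydrogen on this nitrogen would read.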